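Fluoro for methyl on the triazole aryl of compound 3

This account rests on a few compounds, and the source may have more. Where it says the series, first, only, none or still open, it means among the compounds named here.

Compound 1 `Cc1c(O)ccc2c1[C@H](Cn1cc(-c3ccccc3)nn1)[C@@]13CC(=O)[C@@](C)(CC[C@@H]21)C3`: > 20000 nM in a functional assay on SMMC-7721 cells (Homo sapiens) for cytotoxicity, read by MTT assay, with a stated time of 4 days (a higher number here means a weaker inhibitor, a lower number a stronger inhibitor), a limit of the assay rather than a number.
Compound 2 `C=C1C[C@]23C[C@@]1(O)CC[C@H]2c1cc(Br)c(O)c(C)c1[C@@H]3Cn1cc(-c2ccc(Cl)cc2)nn1`: 19100 nM in this assay.
Compound 3 `C=C1C(=O)[C@]23C[C@@]1(O)CC[C@H]2c1ccc(O)c(C)c1[C@@H]3Cn1cc(-c2ccc(C)cc2)nn1`: 920 nM in this assay.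

Of the two numbers given, compound 3 holds the lower one, and the gap from compound 2 to it lies beyond the usual scatter; the third entry is only a limit (the limit of > 20000 nM in this assay, at which 1 of the 3 values shown sits). The next compound, compound 4 `C=C1C(=O)[C@]23C[C@@]1(O)CC[C@H]2c1ccc(O)c(C)c1[C@@H]3Cn1cc(-c2ccc(F)cc2)nn1`, keeps the core of compound 3 and changes one substituent (fluoro in place of methyl on an aromatic carbon). Going by the values given here, no measured pair separates these two groups here, so the step from compound 3 to compound 4 is expected to stay within the scatter, a 1.3-fold higher number from compound 3 to compound 4 (0.12 log units; within the scatter). Compound 4 is therefore estimated at 1200 nM, between 400 nM and 3500 nM.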

Compound 4, half-maximal inhibitory concentration: 850 nM
Compound 4: the middle estimate sits 1.4-fold (0.15 log units) above what was measured; the range from low to high includes it.
By their numbers in this assay, from the lowest: compounds 4 and 3 (each within the scatter of the next); then compound 2. At a limit, above all of these: compound 1.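

In this assay, the change from 4-methylphenyl to 4-fluorophenyl gives a 1.1-fold lower number from compound 3 to compound 4 (0.03 log units; within the scatter). This is the first pair shown that differs in one place, so it shows that, on the core of compound 3, these two substituents at this position cannot be told apart, which the earlier compounds could not show. Nothing among the data shown bears on why the two read alike. On these data alone, whether an amine, a carboxylic acid or a methoxy group at this position would also read alike stays open.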